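Cytotoxicity of aminoglycoside-like compounds with alkyl chains

This account rests on a few compounds, and the source may have more. Where it says the series, first, only, none or still open, it means among the compounds named here.

This study measures how strongly a set of related compounds harm cultured mouse macrophage cells in an ADME assay on J774 cells (Mus musculus) for cytotoxicity, read by MTT assay, with a stated time of 24 h, tested at 30 uM; on this read-out higher numbers stand for a weaker effect at the one concentration tested and lower numbers for a stronger effect. Of the compounds shown here, three have been tested. Compound 1 `CCCCCCCCCCCO[C@@H]1[C@@H](N)[C@@H](O[C@H]2[C@H](O)[C@@H](OCCCCCCC)[C@H](N)C[C@@H]2N)O[C@H](CN)[C@H]1O` gives 39.1%. Compound 2 `CCCCCCCCCCO[C@@H]1[C@@H](N)[C@@H](O[C@H]2[C@H](O)[C@@H](OCCCCCCCCCC)[C@H](N)C[C@@H]2N)O[C@H](CN)[C@H]1O` gives 14.5%, and compound 3 `NC[C@H]1O[C@H](O[C@H]2[C@H](O)[C@@H](OCCCc3ccc4ccccc4c3)[C@H](N)C[C@@H]2N)[C@H](N)[C@@H](OCCCc2ccc3ccccc3c2)[C@@H]1O` gives 89.5%. Among these three numbers compound 1 stands second highest: compound 2 lies below it by a margin beyond the scatter, and compound 3 lies far above it, also beyond the scatter. The order therefore runs from compound 2, the strongest effect, through compound 1 to compound 3, the weakest effect.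

Compound 4 `CCCCCCCO[C@@H]1[C@@H](O)[C@H](O[C@H]2O[C@H](CN)[C@@H](O)[C@H](O)[C@H]2N)[C@@H](N)C[C@H]1N` has not yet been measured in this assay. It differs from compound 1 in one place: hydrogen in place of undecyl on an oxygen on a saturated carbon. The change removes the longer of the two chains of compound 1 and leaves only the heptyl chain on the shared core.

On the numbers shown, compound 2 with two long chains sits lowest and compound 3 highest, so stripping one chain from compound 1 is expected to move the read-out upward, toward a weaker effect, with a step from compound 1 to compound 4 of about a number 40.9 percentage points higher from compound 1 to compound 4 (beyond the scatter). Compound 4 is therefore estimated at 80%, in a range from 55% to 100%.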

Compound 4, a percentage reported as activity, at one concentration (the size of the read-out at that concentration, not a potency): 71.3%
Compound 4: the middle estimate sits 8.7 percentage points above what was measured; measured number inside the range.
By their numbers in this assay, from the lowest: compound 2; then compound 1; then compound 4; then compound 3.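

Swapping undecyloxy for hydroxy, on an oxygen on a saturated carbon, gives the only direct reading so far of what this chain contributes in this assay: the read-out moves by a number 32.2 percentage points higher from compound 1 to compound 4 (beyond the scatter). Among these compounds, none of the earlier compounds could show this, since no two of them differed in one place, so any link between their chains and their numbers remained loose. In this pair the heptyl chain and the shared core stay the same, so the large shift in the read-out goes with the loss of the undecyl chain alone, although nothing shown here explains how that loss spares the cells.

The compounds shown leave open whether the read-out changes gradually or abruptly with chain length at this position, for instance with a butyl chain or a hexadecyl chain in place of undecyl. They also leave open how a benzyl group on the same oxygen would compare, and what removing the heptyl chain instead of the undecyl chain would do.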